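Sulfonate series: aryl substituent swap at the cyclopentylmethyl urea

The source may hold more compounds than are shown below. What is called first, only, known or untested is meant among the compounds shown, and "the series" means these compounds.

The shared core carries a sulfonate ester linking an aniline-derived ring to a substituted phenol. Compound 1 `O=C(CCCCl)Nc1ccc(S(=O)(=O)Oc2ccccc2I)cc1` bears a 3-chloropropyl amide and a 2-iodophenyl ester; in a functional assay on M21 cells (Homo sapiens) for antiproliferative activity, read by sulforhodamine B assay, with a stated time of 48 h (a higher number here means a weaker inhibitor, a lower number a stronger inhibitor), compound 1 gives 7200 nM. Compound 2 `CCNC(=O)Nc1ccc(S(=O)(=O)Oc2ccccc2I)cc1` keeps the iodo ring and carries an ethyl urea instead; in this assay compound 2 gives 5600 nM. Within the data shown here, the step of a 1.3-fold lower number from compound 1 to compound 2 (0.11 log units; within the scatter) is the only measured pair differing in one place, and it concerns the carbonyl substituent, not the ester ring. Compound 3 `CC(C)c1ccccc1OS(=O)(=O)c1ccc(NC(=O)NCC2CCCC2)cc1` combines a cyclopentylmethyl urea with a 2-isopropylphenyl ester; in this assay compound 3 gives 6600 nM. Compound 3 sits within the scatter of both other compounds, compound 1 at 7200 nM and compound 2 at 5600 nM, so no ordering among the three is supported.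

Compound 4 `O=C(NCC1CCCC1)Nc1ccc(S(=O)(=O)Oc2ccccc2I)cc1` differs from compound 3 by iodo in place of isopropyl on an aromatic carbon. Among the measured compounds shown here, no measured step touches this position; compounds 1 and 2, which already carry the iodo ring, give numbers within the scatter of compound 3. The expected step of a 1.0-fold lower number from compound 3 to compound 4 (0.01 log units; within the scatter) is therefore none beyond the scatter. For compound 4 the estimate in this assay is 6500 nM, with a range from 3000 nM to 14000 nM.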

Compound 4, half-maximal inhibitory concentration: 7600 nM
Beside the measured number, compound 4's estimate is 1.2-fold (0.07 log units) below it; measured number inside the range.
By their numbers in this assay, from the lowest: compounds 2, 3, 1 and 4 (each within the scatter of the next).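

In this assay the change from 2-isopropylphenyl to 2-iodophenyl at the cyclopentylmethyl urea gives a 1.2-fold higher number from compound 3 to compound 4 (0.06 log units; within the scatter) and is the only step shown on this aromatic carbon, ortho to a large group. Iodo, with one heavy atom, and isopropyl, with three carbons, are not told apart here, so this position has so far shown no measurable response to the swap. With the 2-iodophenyl ester held fixed, the other side of the molecule is not told apart either: cyclopentyl in place of methyl gives a 1.4-fold higher number from compound 2 to compound 4 (0.13 log units; within the scatter) and (cyclopentylmethyl)amino in place of 3-chloropropyl gives a 1.1-fold higher number from compound 1 to compound 4 (0.02 log units; within the scatter) and all of these steps stay within the scatter, while no measurement on hand offers an explanation for the flat result.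

From the compounds shown here alone, whether an amine or a carboxylic acid in place of iodo on this aromatic carbon would give a step beyond the scatter stays open. It is equally open whether a longer chain or a piperidine ring on the urea nitrogen would separate any compound from the four shown.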